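Chain extension at the amino substituent of the shared core

The source may report more compounds than this note shows. Statements on the series, on what has been measured and on what is new or still open speak of the compounds shown alone.

Compound 1 `CNc1nc(-c2ccccc2)nc2c1nnn2Cc1ccccc1Cl` and compound 2 `CCNc1nc(-c2ccccc2)nc2c1nnn2Cc1ccccc1Cl` share one core; in an assay on Cerebral cortex for displacement of a labelled ligand from adenosine receptor A1 (Bos taurus) (a lower number here means a stronger inhibitor, a higher number a weaker inhibitor), compound 1 gives 191 nM and compound 2 gives 463 nM. The change between them, (methyl in place of hydrogen on a saturated chain carbon bound to a nitrogen on an aromatic ring), made a step of a 2.4-fold higher number from compound 1 to compound 2 (0.38 log units; beyond the scatter). Compound 3 `CCCNc1nc(-c2ccccc2)nc2c1nnn2Cc1ccccc1` gives 37 nM in this assay; the difference between its core and that of compound 1 is not broken down here. Compound 4 `CCCCNc1nc(-c2ccccc2)nc2c1nnn2Cc1ccccc1` is not yet measured and differs from compound 3 by methyl in place of hydrogen on a saturated chain carbon, three bonds along the chain from a nitrogen on an aromatic ring. This is the same kind of change as that from compound 1 to compound 2, not the same: there the entering methyl sat on a saturated chain carbon bound to a nitrogen on an aromatic ring, here it sits three bonds along the chain from such a nitrogen. The step is expected to be a 1.5-fold higher number from compound 3 to compound 4 (0.17 log units; within the scatter), resting on the earlier 2.4-fold higher number from compound 1 to compound 2 (0.38 log units; beyond the scatter) and on the place lying further from the ring, which suggests a smaller shift. Compound 4 is expected to give 55 nM, between 25 nM and 120 nM.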

Compound 4, inhibition constant: 11 nM
The estimate for compound 4 lay 5.0-fold (0.70 log units) above the measured number, and the stated range ends above it.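

Adding the methyl gave a 3.4-fold lower number from compound 3 to compound 4 (0.53 log units; beyond the scatter) in this assay. The change therefore does not carry over from one core to the other, in size or in direction: the same change on two cores in this assay, a 2.4-fold higher number (0.38 log units; beyond the scatter) from compound 1 to compound 2 and a 3.4-fold lower number (0.53 log units; beyond the scatter) from compound 3 to compound 4, 8.2-fold (0.91 log units) apart, beyond the scatter of two such steps

The two pairs differ in the core and also in the place of the methyl, on the chain carbon bound to the nitrogen in one pair and three bonds along the chain in the other, and these steps do not separate those two differences.

Still open, on these data alone, is how propyl and butyl chains behave on the core of compound 1, which would separate core from place. Also open, as far as these compounds go, is whether a longer chain, such as pentyl, or an amine at the chain end would lower the number further.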